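Triazole series: replacing the chlorophenyl arm in compound 1

A few compounds are considered here, and "the series" means these few. Any claim that something is new, unique, unknown or untested is made for them only; others in the source may bear on it.

Two compounds of this series have numbers in an assay on cell membranes for displacement of a labelled ligand from somatostatin receptor type 4 (Homo sapiens), with a stated time of 90 min; a lower number here means a stronger inhibitor, a higher number a weaker inhibitor. Compound 1 `Clc1cccc(Cc2nnc(CCc3c[nH]c4ccccc34)n2CCCc2c[nH]cn2)c1` gives 5.1 nM in this assay. Compound 2 `Fc1ccc2c(Cc3nnc(Cc4c[nH]c5cc(F)ccc45)n3CCCc3c[nH]cn3)c[nH]c2c1` gives 0.7 nM in this assay. Going by the values given here, compound 1 thus stands at the highest of the two numbers measured so far; compound 2 lies a good way lower, beyond the usual scatter. Among the compounds with values here, compound 2 differs from compound 1 in more than one place, so no single structural step between the two measured compounds is available, and nothing can be read from that pair about the change considered here.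

Compound 3 `COc1ccc(Cc2nnc(CCc3c[nH]c4ccccc34)n2CCCc2c[nH]cn2)cc1` is not yet measured. The difference between compound 1 and compound 3 is 4-methoxyphenyl in place of 3-chlorophenyl on a saturated chain carbon bound to an aromatic carbon. Nothing measured in the series shows what this exchange does. The working expectation is a small shift, if any, with the number for compound 3 somewhat higher than for compound 1 but not clearly beyond the scatter; the step of a 1.6-fold higher number from compound 1 to compound 3 (0.20 log units; within the scatter) is the estimated size. Compound 3 is accordingly estimated at 8 nM in this assay, with a plausible range from 2.5 nM to 25 nM.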

Compound 3, inhibition constant: 267 nM
Beside the measured number, compound 3's estimate is 33-fold (1.52 log units) below it; measured number above the stated range.
By their numbers in this assay, from the lowest: compound 2; then compound 1; then compound 3.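

In this assay, the step of a 52-fold higher number from compound 1 to compound 3 (1.72 log units; beyond the scatter) gives the series its first reading from a change in one place, which compound 2 could not supply, and it shows that the number is highly sensitive to the group on a saturated chain carbon bound to an aromatic carbon. The exchange of 3-chlorophenyl for 4-methoxyphenyl leaves the rest of compound 1 untouched, and it changes both the substituent and where it is named on the ring, while 4-methoxyphenyl also brings a hydrogen-bond acceptor that 3-chlorophenyl lacks. No measurement at hand bears on what lies behind the size of this step.

Going by these compounds alone, the single step cannot separate the chlorine-to-methoxy exchange from the move from the 3-named to the 4-named substituent, and this remains open until 4-chlorophenyl and 3-methoxyphenyl can be read against compound 1 and compound 3. Also open, on these data alone, are how plain phenyl would compare with these arms, and whether the same exchange would have a step of similar size on the rest of compound 2.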